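One Added Methyl and a Half-Life Estimate

The source may hold more compounds than are shown below. What is called first, only, known or untested is meant among the compounds shown, and "the series" means these compounds.

Measured in a physicochemical assay for metabolic stability, in phosphate buffer, at pH 7.4; on this read-out higher numbers stand for a longer-lived compound and lower numbers for a shorter-lived compound:
Compound 1 `Cc1nc(C)c(COC(=O)N[C@H](C)C(=O)Oc2ccc(-c3cc(=O)c4c(O)c(O)c(O)cc4o3)cc2)nc1C`: 27.8 h
Compound 2 `Cc1nc(C)c(COC(=O)N[C@@H](C(=O)Oc2ccc(-c3cc(=O)c4c(O)c(O)c(O)cc4o3)cc2)C(C)C)nc1C`: 45.6 h

For the measured compounds named here, compound 2, at 45.6 h, stands within the scatter of compound 1, the only other measured compound. Compound 3 `CC[C@H](C)[C@@H](NC(=O)OCc1nc(C)c(C)nc1C)C(=O)Oc1ccc(-c2cc(=O)c3c(O)c(O)c(O)cc3o2)cc1` differs from compound 2 by methyl in place of hydrogen on a saturated chain carbon, three bonds along the chain from an amide-type nitrogen and a carbonyl carbon, which reads as isopropyl to sec-butyl. Going by the values given here, the one measured step that bears on this change, isopropyl in place of methyl, is a 1.6-fold higher number from compound 1 to compound 2 (0.21 log units; within the scatter). Among the compounds with values here, with only that step to go on, no change beyond the scatter is expected in this assay, and the estimated step is a 1.1-fold higher number from compound 2 to compound 3 (0.04 log units; within the scatter). Compound 3 is expected at 50 h, with an estimated range of 24 h to 100 h.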

Compound 3, half-life: 64.8 h
Beside the measured number, compound 3's estimate is 1.3-fold (0.11 log units) below it, and the stated range covers the measured number.
By their numbers in this assay, from the lowest: compounds 1, 2 and 3 (each within the scatter of the next, the first and the last beyond it).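

In this assay the added methyl, isopropyl to sec-butyl, gives a 1.4-fold higher number from compound 2 to compound 3 (0.15 log units; within the scatter) and so does not by itself separate these two compounds. Sec-butyl in place of methyl on the saturated chain carbon bound to an amide-type nitrogen and a carbonyl carbon gives a 2.3-fold higher number from compound 1 to compound 3 (0.37 log units; beyond the scatter) and is the first step at this position to pass the scatter, though only modestly. No evidence bears on what lies behind these numbers. The compounds shown leave open how a longer straight chain, a benzyl group or a carboxylic acid on this carbon would read in this assay and whether the rise would continue.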